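The compounds below may be only part of what the source reports. "The series", "measured", "known", "first", "only" and "open" are said of these compounds alone.

Measured compounds in an ADME assay on the whole organism (plasma, strain Beagle) for pharmacokinetics, with Canis familiaris (Canis lupus familiaris) as the target, read by LC-MS, with a stated time of 8 h, at a dose of 10 mg/kg by the intraduodenal route; a higher number here means more compound in the circulation at the dose given, a lower number less compound in the circulation:
- compound 1 `COC(=O)C1=C(S[C@@H]2CN[C@H](C(=O)Nc3cccc(C(=O)OC)c3)C2)[C@H](C)[C@@H]2[C@@H]([C@@H](C)O)C(=O)N12`: 403 ng.h/mL
- compound 2 `CCOC(=O)C1=C(S[C@@H]2CN[C@H](C(=O)Nc3cccc(C(=O)OCC)c3)C2)[C@H](C)[C@@H]2[C@@H]([C@@H](C)OC(=O)[C@@H](N)C(C)C)C(=O)N12`: "below limit of detection" (no number reported)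
- compound 3 `C[C@@H](O)[C@H]1C(=O)N2C(C(=O)OCOC(=O)C(C)(C)C)=C(S[C@@H]3CN[C@H](C(=O)Nc4cccc(C(=O)OCOC(=O)C(C)(C)C)c4)C3)[C@H](C)[C@H]12`: "below limit of detection" (no number reported)

Compound 2 stands without a number in this assay; its entry is a limit of the assay, not a value. Compound 3 likewise gives only a limit in this assay. Going by the values given here, compound 1 is the one compound of the set with a number, and it stands with a free hydroxyl on the shared core, as compound 4 does.

The step from compound 2 to compound 4 `CCOC(=O)C1=C(S[C@@H]2CN[C@H](C(=O)Nc3cccc(C(=O)OCC)c3)C2)[C@H](C)[C@@H]2[C@@H]([C@@H](C)O)C(=O)N12` is hydrogen in place of (1-amino-2-methylpropyl)carbonyl on an oxygen on a saturated carbon. Among the compounds with values here, no step between measured compounds with this difference is known, so the size cannot be read from a measured pair; compound 1 and compound 3 both carry the hydroxyl that compound 4 carries, and one of them has a number while the other has a limit. The direction expected is upward from the limit of compound 2, but the span is wide.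

Compound 4 is expected at 200 ng.h/mL, with a range from 30 ng.h/mL to 900 ng.h/mL, because compound 1 gives 403 ng.h/mL while sharing the free hydroxyl with compound 4.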

Compound 4, area under the concentration-time curve: 2660 ng.h/mL
Compound 4: the middle estimate sits 13-fold (1.12 log units) below what was measured, outside the stated range (above it).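

No step can be read from compound 2 to compound 4 in this assay, as compound 2 has only a limit of the assay and no number. No evidence on hand bears on this result. The compounds shown leave open the size of the difference between ((1-amino-2-methylpropyl)carbonyl)oxy and hydroxy in this assay.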